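Changing the Ester Group and Microsomal Half-Life

The compounds below may be only part of what the source reports. "The series", "measured", "known", "first", "only" and "open" are said of these compounds alone.

Compound 1, `CCOc1cc(NC(=O)C2(NC(=O)c3ccc4c(C5CCCC5)c(-c5ncc(Cl)cn5)n(C)c4c3)CCC2)ccc1/C=C/C(=O)OC(=O)C[C@H](O)C(=O)O`: 7.92 h
Compound 2, `CCOc1cc(NC(=O)C2(NC(=O)c3ccc4c(C5CCCC5)c(-c5ncc(Cl)cn5)n(C)c4c3)CCC2)ccc1/C=C/C(=O)OCC(C)C`: 1.42 h
Compound 3, `CCOc1cc(NC(=O)C2(NC(=O)c3ccc4c(C5CCCC5)c(-c5ncc(Cl)cn5)n(C)c4c3)CCC2)ccc1/C=C/C(=O)OCc1ccccc1`: 2.17 h

These three compounds share one core and differ only in the group on an oxygen next to a carbonyl group. In an ADME assay (liver) for pharmacokinetics, with Liver microsome (Rattus norvegicus) as the target, using microsomes (on this read-out lower numbers stand for a shorter-lived compound and higher numbers for a longer-lived compound), compound 1 gives the highest of the three numbers; compound 3 comes nearest to it, and compound 2 lies furthest away. Compound 4, `CCOc1cc(NC(=O)C2(NC(=O)c3ccc4c(C5CCCC5)c(-c5ncc(Cl)cn5)n(C)c4c3)CCC2)ccc1/C=C/C(=O)OCC(N)=O`, is not yet measured. It differs from compound 1 in one place: carbamoylmethyl in place of (2-carboxy-2-hydroxyethyl)carbonyl on an oxygen next to a carbonyl group.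

Two measured steps replace the same group at the same place and so bear on this change. Because the steps of a 5.6-fold lower number from compound 1 to compound 2 (0.75 log units; beyond the scatter) and a 3.6-fold lower number from compound 1 to compound 3 (0.56 log units; beyond the scatter) both lower the number beyond the scatter, a downward step is expected for compound 4 as well, whereas the step of a 1.5-fold higher number from compound 2 to compound 3 (0.18 log units; within the scatter) stays within the scatter. The carbamoylmethyl group itself has not been tested here, so the exact size is uncertain, but a modest shortening is the expectation. Compound 4 is therefore estimated at 2.5 h, with a range from 1 h to 6 h. This corresponds to an expected step of a 3.2-fold lower number from compound 1 to compound 4 (0.50 log units; beyond the scatter).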

Compound 4, half-life: 0.383 h
The estimate for compound 4 lay 6.5-fold (0.81 log units) above the measured number; measured number outside the range, below it.
By their numbers in this assay, from the lowest: compound 4; then compounds 2 and 3 (each within the scatter of the next); then compound 1.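

In this assay, carbamoylmethyl on this oxygen gives the largest drop seen at this position, a 21-fold lower number from compound 1 to compound 4 (1.32 log units; beyond the scatter), so the size of the step depends heavily on which group enters, not only on the loss of (2-carboxy-2-hydroxyethyl)carbonyl. Isobutyl and benzyl lay within the scatter of each other, which left open the idea that replacements here might all land in one narrow band, but carbamoylmethyl falls clearly outside it, with a 5.7-fold lower number from compound 3 to compound 4 (0.75 log units; beyond the scatter) and a 3.7-fold lower number from compound 2 to compound 4 (0.57 log units; beyond the scatter), both beyond the scatter. Among the four compounds, this places compound 4 as the shortest-lived and leaves compound 1 as the longest-lived, with compounds 2 and 3 in the middle.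

Nothing measured here explains why these groups differ as they do. The compounds shown also leave open which part of (2-carboxy-2-hydroxyethyl)carbonyl goes with the longest half-life, and whether a group such as carboxymethyl, 2-aminoethyl or a longer chain ending in carbamoyl would land nearer compound 1 or compound 4.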